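The source may hold more compounds than are shown below. What is called first, only, known or untested is meant among the compounds shown, and "the series" means these compounds.

Three compounds have been measured so far:
compound 1, `Cn1c(=O)[nH]c2ccc(OCc3ccc(Cl)cc3)cc21`, 8.29%;
compound 2, `Cn1c(=O)[nH]c2ccc(OCc3ccc(Cl)c(Cl)c3)cc21`, 32.4%;
compound 3, `O=C1Nc2ccc(OCc3cccc(Cl)c3)cc2C1=O`, 93%.

All three numbers come from an assay on cells for inhibition of Amine oxidase [flavin-containing] B (Homo sapiens), read by fluorescence, with stated times of 30 min and 15 min, tested at 1 uM; a higher number here means more inhibition at the concentration tested (going by the name of the read-out), a lower number less inhibition. Compound 1 and compound 2 share one core; the change chloro in place of hydrogen on an aromatic carbon made a step of a number 24.1 percentage points higher from compound 1 to compound 2 (beyond the scatter). Compound 3 is built on a different core, and the difference between the two cores is not broken down here. Among the three, compound 3 gives the highest number, and its gaps to compound 1 and to compound 2 both lie beyond the scatter.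

Compound 4, `O=C1Nc2ccc(OCc3ccc(Cl)c(Cl)c3)cc2C1=O`, has not yet been measured. It differs from compound 3 by chloro in place of hydrogen on an aromatic carbon. Among the compounds with values here, this is the same kind of change as the one from compound 1 to compound 2, though not the same: in compound 2 the entering chloro sits meta to a large group, in compound 4 it sits para to a large group. Because compound 3 already gives 93%, little room remains in this assay, so only a small step is expected, a number 2 percentage points higher from compound 3 to compound 4 (within the scatter), clearly smaller than the earlier one. Compound 4 is therefore expected to give about 95%, between 86% and 99%.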

Compound 4, a percentage reported as inhibition, at one concentration (the size of the read-out at that concentration, not a potency): 95.7%
Compound 4: middle estimate off by 0.7 percentage points, on the low side; low and high end bracket the measured number.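

In this assay, chloro in place of hydrogen on an aromatic carbon made a step of a number 2.7 percentage points higher from compound 3 to compound 4 (within the scatter), so on this core the added chloro leaves the reading practically unchanged. The change therefore does not carry over at the same size from one core to the other: the same change on two cores in this assay, a number 24.1 percentage points higher (beyond the scatter) from compound 1 to compound 2 and a number 2.7 percentage points higher (within the scatter) from compound 3 to compound 4, 21.4 percentage points apart, beyond the scatter of two such steps This does not show that the core of compound 3 is by nature less responsive to the change, as compound 3 already gives 93%, close to the top of a percentage scale, and a reading at a single concentration cannot separate compounds whose numbers all lie near that top.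

Every compound shown carries only chloro on the ring that takes this change, which leaves open how a fluoro, a methoxy, a nitrile, an amine or a carboxylic acid there would behave on either core. Also open, on these data alone, is whether compound 3 and compound 4 would differ at a lower test concentration, where the reading would have more room to move.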